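Benzyl Ethyl Amine in Place of Two Isopentyl Chains

A few compounds are considered here, and "the series" means these few. Any claim that something is new, unique, unknown or untested is made for them only; others in the source may bear on it.

Going by the values given here, compound 1 `CC(C)CCN(CCC(C)C)c1cccc(C(=O)N2CCc3ccc(OS(N)(=O)=O)cc3C2)c1` carries a diisopentylamino group on an aromatic carbon and stands highest of the two numbers measured so far: in an assay on HEK293 cells for inhibition of Steryl-sulfatase (Homo sapiens), tested at 0.1 uM (on this read-out lower numbers stand for a weaker effect and higher numbers for a stronger effect at the one concentration tested), compound 1 gives 32.3%. Among the compounds with values here, the only other measured compound, compound 2 `CN(CCN1CCCCC1)c1ccc(C(=O)N2CCc3ccc(OS(N)(=O)=O)cc3C2)cc1`, gives 0.3% in this assay, a number lower by a margin beyond the usual scatter. Within the data shown here, the two differ in more than one place, so no single step between them can be drawn; their values only show that the pair spans a wide range.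

Compound 3 `CCN(Cc1ccccc1)c1cccc(C(=O)N2CCc3ccc(OS(N)(=O)=O)cc3C2)c1` has not yet been measured. It differs from compound 1 in one place: benzyl(ethyl)amino in place of diisopentylamino on an aromatic carbon. Among the measured compounds shown here, no measured step of this kind exists, so the expectation rests on compound 1 alone. A modest decrease is expected, a number 10.3 percentage points lower from compound 1 to compound 3 (beyond the scatter), at the edge of the scatter rather than far beyond it, because compound 1 sits at 32.3% and the exchange keeps a tertiary amine of comparable size in the same place. Compound 3 is therefore estimated at 22%, with a range from 8% to 38%.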

Compound 3, a percentage reported as inhibition, at one concentration (the size of the read-out at that concentration, not a potency): 17.3%
Estimate against measurement, compound 3: 4.7 percentage points above; measured number inside the range.
By their numbers in this assay, from the lowest: compound 2; then compound 3; then compound 1.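

In this assay, going by these compounds alone, the exchange of diisopentylamino for benzyl(ethyl)amino gives a number 15 percentage points lower from compound 1 to compound 3 (beyond the scatter) and so provides the first single-place comparison at this aromatic carbon, a modest step. The change replaces two open isopentyl chains with an ethyl chain and a benzyl group, which brings in one six-membered aromatic ring of carbon only, while the hydrogen-bond counts and the absence of a net charge stay the same. It shows that this position accepts a ring-bearing tertiary amine with a measurable read-out at the one concentration tested, but with a lower number than the diisopentylamino group of compound 1, and nothing shown here accounts for that difference.

Both arms of the amine change together, so the compounds shown do not separate the contribution of the benzyl group from that of the ethyl chain; a benzyl(isopentyl)amino or a dibenzylamino group at the same place would bear on that question. Also open, as far as these compounds go, is how a smaller diethylamino group or a piperidine ring at this aromatic carbon would compare with compound 1.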